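Hydroxymethyl Added to the Pyrimidine of a Chloro Analogue

The compounds below may be only part of what the source reports. "The series", "measured", "known", "first", "only" and "open" are said of these compounds alone.

Three anilines on one shared core have been measured in a functional assay on MT2 cells (Homo sapiens) for cytotoxicity, read by MTT assay; a lower number here means that less compound is tolerated, a higher number that more compound is tolerated. Compound 1 `CC(C)=CCOc1cc(Nc2ccccn2)ccc1C` gives 35000 nM. Compound 2 `CC(C)=CCOc1cc(Nc2ncccn2)ccc1C` gives 78000 nM, reached by a modest step, a 2.2-fold higher number from compound 1 to compound 2 (0.35 log units; beyond the scatter). Compound 3 `CC(C)=CCOc1cc(Nc2ncccn2)ccc1Cl` gives 2500 nM, the lowest number of the three, reached by a large step, a 31-fold lower number from compound 2 to compound 3 (1.49 log units; beyond the scatter); the value of compound 1 is the nearest to it and still well above it.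

Compound 4 `CC(C)=CCOc1cc(Nc2nccc(CO)n2)ccc1Cl` differs from compound 3 by hydroxymethyl in place of hydrogen on an aromatic carbon, the new group standing on an aromatic carbon of a six-membered aromatic ring with 2 nitrogen, next to the ring nitrogen and opposite the ring nitrogen. Going by the values given here, neither measured step speaks to this change: the first exchanged pyridin-2-yl for pyrimidin-2-yl, the second put chloro in place of methyl on the other ring, and no measured pair varies a substituent on the pyrimidin-2-yl itself.

With nothing pointing either way, the expectation is a step for compound 4 of no more than the scatter, a 1.6-fold higher number from compound 3 to compound 4 (0.20 log units; within the scatter), leaning if anything toward a slightly higher number. Compound 4 is therefore estimated at 4000 nM in this assay, within 1500 nM to 12000 nM.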

Compound 4, half-maximal cytotoxic concentration: 220 nM
Beside the measured number, compound 4's estimate is 18-fold (1.26 log units) above it, outside the stated range (below it).
By their numbers in this assay, from the lowest: compound 4; then compound 3; then compound 1; then compound 2.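

The first substituent seen on the pyrimidin-2-yl itself moves the number in this assay well beyond the scatter: hydroxymethyl in place of hydrogen gives an 11-fold lower number from compound 3 to compound 4 (1.06 log units; beyond the scatter). This aromatic carbon, opposite the ring nitrogen, is therefore a place where a small change of 2 heavy atoms matters to how much compound the MT2 cells tolerate, and the result adds a second large lowering of the number to the one on the other ring, a 31-fold lower number from compound 2 to compound 3 (1.49 log units; beyond the scatter), so both rings of the shared core now carry a change that lowers it. No measurement available here accounts for the size of this step or says what the hydroxymethyl does in the cells.

The compounds shown leave open whether the step belongs to the hydroxymethyl as such or would also follow from a plain methyl, a methoxymethyl, an aminomethyl or a carboxylic acid on the same carbon. They also leave open whether hydroxymethyl would lower the number as far with methyl in place of chloro on the other ring, or with a pyridin-2-yl carrying the same group.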